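Swapping Chloro for Trifluoromethyl: Expectation for Compound 4

The source may report more compounds than this note shows. Statements on the series, on what has been measured and on what is new or still open speak of the compounds shown alone.

Compound 1, `O=C(/C=C/c1ccccc1)c1ccc(N2CCN(c3ccc([N+](=O)[O-])cc3)CC2)cc1`: 55.4%
Compound 2, `O=C(/C=C/c1ccccc1)c1ccc(N2CCN(c3cccc(Cl)c3)CC2)cc1`: 14.1%
Compound 3, `COc1cccc(N2CCN(c3ccc(C(=O)/C=C/c4ccccc4)cc3)CC2)c1`: 16%

All three were tested in a functional assay on the whole organism (strain Kunming) for inhibition, with Mus musculus as the target, with a stated time of 1 h, at a dose of 40 mg/kg by the oral route; a higher number here means more inhibition at the dose given (going by the name of the read-out), a lower number less inhibition. Compound 2 has the lowest of the three numbers; its gap to compound 3 is within the usual scatter, whereas the drop a number 41.3 percentage points lower from compound 1 to compound 2 (beyond the scatter) is large and beyond it. Compound 4, `O=C(/C=C/c1ccccc1)c1ccc(N2CCN(c3cccc(C(F)(F)F)c3)CC2)cc1`, is not yet measured and differs from compound 2 in one place: trifluoromethyl in place of chloro on an aromatic carbon. Among the measured compounds shown here, the one step that resembles it, another swap of a small group on that aromatic carbon, was a number 1.9 percentage points higher from compound 2 to compound 3 (within the scatter), within the scatter. The large steps of a number 41.3 percentage points lower from compound 1 to compound 2 (beyond the scatter) and a number 39.4 percentage points lower from compound 1 to compound 3 (beyond the scatter) concern a different group and do not bear on it. Therefore no step beyond the scatter is expected in this assay . Compound 4 is estimated at 15% (range 4% to 30%), which means an expected step of a number 0.9 percentage points higher from compound 2 to compound 4 (within the scatter).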

Compound 4, a percentage reported as inhibition, in the whole organism at one dose (the size of the read-out at that dose, not a potency): 25%
Estimate against measurement, compound 4: 10 percentage points below, within the range that was stated.
By their numbers in this assay, from the lowest: compounds 2, 3 and 4 (each within the scatter of the next, the first and the last beyond it); then compound 1.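

In this assay the group on this aromatic carbon can shift the number: trifluoromethyl in place of chloro gives a number 10.9 percentage points higher from compound 2 to compound 4 (beyond the scatter), whereas trifluoromethyl in place of methoxy gives a number 9 percentage points higher from compound 3 to compound 4 (within the scatter). Even so, 3-(trifluoromethyl)phenyl in place of 4-nitrophenyl still leaves a number 30.4 percentage points lower from compound 1 to compound 4 (beyond the scatter). Nothing at hand accounts for the step from chloro to trifluoromethyl. Still open, on these data alone, is whether an amine or a carboxylic acid on this aromatic carbon would move the number further. Also open, as far as these compounds go, is whether the higher number of compound 1 follows the nitro group itself or its place on the ring.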